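The source may hold more compounds than are shown below. What is called first, only, known or untested is meant among the compounds shown, and "the series" means these compounds.

Compound 2 `O=c1cc(-c2ccccc2)oc2ccc(N3COc4ccccc4C3)cc12` stands highest of the two numbers measured in a functional assay on MCF7 cells (Homo sapiens) for inhibition, read by MTT assay, with a stated time of 48 h, tested at 60 ug/mL (on this read-out higher numbers stand for more inhibition of growth at the one concentration tested and lower numbers for less inhibition of growth), where compound 2 gives 92.7%; compound 1 `O=c1cc(-c2ccccc2)oc2ccc(N3COc4c(Br)cc(Br)cc4C3)cc12` gives 34.5% in this assay, a gap beyond the usual scatter. Compound 3 `O=c1cc(-c2ccccc2)oc2ccc(N3COc4c(Br)cccc4C3)cc12` differs from compound 2 by bromo in place of hydrogen on an aromatic carbon. Within the data shown here, no step between measured compounds shows what a single such change does; compound 1 carries two bromo groups and sits far lower. A drop beyond the scatter, though smaller than the gap to compound 1, is expected for the step of a number 27.7 percentage points lower from compound 2 to compound 3 (beyond the scatter). Compound 3 is estimated at 65%, between 40% and 90%.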

Compound 3, percent growth inhibition at one concentration: 81.8%
Estimate against measurement, compound 3: 16.8 percentage points below; measured number inside the range.
By their numbers in this assay, from the lowest: compound 1; then compound 3; then compound 2.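

Bromo in place of hydrogen on this aromatic carbon shows as a number 10.9 percentage points lower from compound 2 to compound 3 (beyond the scatter) in this assay and is a modest step, so compound 3 keeps most of the growth inhibition. Most of the loss in compound 1 therefore goes with its other bromo, whose replacement by hydrogen gives a number 47.3 percentage points higher from compound 1 to compound 3 (beyond the scatter) as a large step. Nothing available explains either step.

As far as these compounds go, whether an amine or a methoxy group on this same carbon would keep the inhibition remains open. Also open, from the compounds shown here alone, is how compound 2 would respond to bromo on the other carbon alone.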